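Pyrimidine substituent variation on the piperazine arm

A few compounds are considered here, and "the series" means these few. Any claim that something is new, unique, unknown or untested is made for them only; others in the source may bear on it.

Measured compounds:
- compound 1 `CC#CCn1c(N2CCC[C@@H](N)C2)nc2c1c(=O)n(CCCN1CCN(c3nc(-c4ccccc4)cs3)CC1)c(=O)n2C`: 650 nM
- compound 2 `CC#CCn1c(N2CCC[C@@H](N)C2)nc2c1c(=O)n(CCCN1CCN(c3ncc(CCC)cn3)CC1)c(=O)n2C`: 1850 nM
- compound 3 `CC#CCn1c(N2CCC[C@@H](N)C2)nc2c1c(=O)n(CCCN1CCN(c3ncc(C(F)(F)F)cn3)CC1)c(=O)n2C`: 4020 nM

All three share one core and differ only in the aryl group on the amine nitrogen of the piperazine ring. In a functional assay on HEK293 cells for agonist activity at Glucose-dependent insulinotropic receptor (Homo sapiens), read by a luciferase reporter (a lower number here means that less compound is needed, a higher number that more compound is needed for the effect), compound 1 gives 650 nM, the lowest of the three numbers. Compound 3 stands at the top: a 6.2-fold higher number from compound 1 to compound 3 (0.79 log units; beyond the scatter) and a 2.2-fold higher number from compound 2 to compound 3 (0.34 log units; beyond the scatter), both beyond the scatter, and a 2.8-fold higher number from compound 1 to compound 2 (0.45 log units; beyond the scatter) places compound 2 between them.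

Compound 4 `CC#CCn1c(N2CCC[C@@H](N)C2)nc2c1c(=O)n(CCCN1CCN(c3ncc(F)cn3)CC1)c(=O)n2C` is not yet measured. It differs from compound 3 in one place: fluoro in place of trifluoromethyl on an aromatic carbon. Among the compounds with values here, the only measured step at this same aromatic carbon is a 2.2-fold higher number from compound 2 to compound 3 (0.34 log units; beyond the scatter), where propyl was exchanged for trifluoromethyl. No measured compound carries fluoro at this position, so the size of the step from trifluoromethyl to fluoro has no direct precedent among these three compounds; the propyl-to-trifluoromethyl step is the nearest guide and was modest.

For compound 4 a modest drop in number relative to compound 3 is expected, a 1.7-fold lower number from compound 3 to compound 4 (0.22 log units; within the scatter), landing near the value of compound 2. The estimate for compound 4 in this assay is 2400 nM, with a range from 1000 nM to 6000 nM.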

Compound 4, half-maximal effective concentration: 1410 nM
For compound 4 the middle estimate is 1.7-fold (0.23 log units) above the measured one; measured number inside the range.
By their numbers in this assay, from the lowest: compound 1; then compounds 4 and 2 (each within the scatter of the next); then compound 3.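

In this assay, within the data shown here, fluoro in place of trifluoromethyl on the aromatic carbon para to a large group gives a 2.9-fold lower number from compound 3 to compound 4 (0.46 log units; beyond the scatter), the first measured step at this position that leaves trifluoromethyl for a single fluorine. The exchange of propyl for fluoro gives a 1.3-fold lower number from compound 2 to compound 4 (0.12 log units; within the scatter), so these two groups are not told apart in this assay, and among the three 5-substituted pyrimidin-2-yl compounds, compound 3 alone stands apart, with trifluoromethyl; the position therefore tolerates both the one-atom fluoro and the longer propyl without a separation between them. Even so, the pyrimidine arm does not match the thiazole arm, with a 2.2-fold higher number from compound 1 to compound 4 (0.34 log units; beyond the scatter) for 5-fluoropyrimidin-2-yl in place of 4-phenyl-1,3-thiazol-2-yl, which leaves compound 1 with the lowest number of the four.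

Nothing available here accounts for the higher number of compound 3 or for the lack of separation between fluoro and propyl. Still open, from the compounds shown here alone, is whether a phenyl ring, a methoxy group, an amine or a carboxylic acid on this aromatic carbon would bring a pyrimidine compound closer to compound 1 or push it towards compound 3.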